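Ring-nitrogen substitution in the 3-nitrophenyl series

This account rests on a few compounds, and the source may have more. Where it says the series, first, only, none or still open, it means among the compounds named here.

Compound 1 `Cc1cc2nc(-c3cccc([N+](=O)[O-])c3)c(=O)n(Cc3ccccc3)c2cc1C` is the benzylated, dimethylated member. In an assay on cells for activation of Cystic fibrosis transmembrane conductance regulator (Homo sapiens), read by fluorescence, with a stated time of 10 min (on this read-out higher numbers stand for an effect only at larger amounts of compound and lower numbers for an effect already at smaller amounts), compound 1 gives only a limit, > 10000 nM. Compound 2 `O=c1[nH]c2ccccc2nc1-c1cccc([N+](=O)[O-])c1` carries hydrogen on the aromatic nitrogen. In this assay compound 2 likewise gives only a limit, > 10000 nM. Both values sit at the limit of > 10000 nM in this assay, at which 2 of the 2 values shown sit, so compound 2 cannot be ranked on the numbers shown. Compound 3 `O=c1c(-c2cccc([N+](=O)[O-])c2)nc2ccccc2n1Cc1ccccn1` differs from compound 2 by (pyridin-2-yl)methyl in place of hydrogen on an aromatic nitrogen, in words (pyridin-2-yl)methyl in place of hydrogen on an aromatic nitrogen. Among the measured compounds shown here, no measured pair isolates this change, and the related substitution carried by compound 1 also gave only a limit. The expected step is a step that the limit leaves unreadable from compound 2 to compound 3, nothing beyond the scatter. Compound 3 is estimated at 12000 nM, between 3000 nM and 40000 nM, most likely reported again as a limit.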

Compound 3, half-maximal effective concentration: 52 nM
Beside the measured number, compound 3's estimate is 230-fold (2.36 log units) above it; the measured number lies below the stated range.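

The aromatic nitrogen opposite the ring nitrogen is a position where the read-out responds strongly: in this assay, (pyridin-2-yl)methyl in place of hydrogen gives an at least 190-fold lower number from compound 2 to compound 3 (2.28 log units; beyond the scatter) on the shared core. That step has only a floor, because its starting value is a limit: the limit of > 10000 nM in this assay, at which 2 of the 3 values shown sit. Compound 1 gives the limit > 10000 nM despite its benzyl group on that nitrogen, and it differs from compound 3 in more than one place.

On these data alone, whether the ring nitrogen of (pyridin-2-yl)methyl is needed remains open. Also open, as far as these compounds go, is how benzyl alone on the unmethylated core, a longer chain or an amine would read at this position.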